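Swapping the Trimethylphenyl Arm for a Chloro-dimethoxyphenyl

The compounds below may be only part of what the source reports. "The series", "measured", "known", "first", "only" and "open" are said of these compounds alone.

Compound 1 `CCc1ccccc1-n1nncc1CN1C(=O)C2(C(C#N)=C(N)Oc3c(N)cc4nc5ccccc5nc4c32)c2ccccc21`, compound 2 `N#CC1=C(N)Oc2c(N)cc3nc4ccccc4nc3c2C12C(=O)N(Cc1cnnn1-c1ccccc1Br)c1ccccc12` and compound 3 `Cc1cc(C)c(-n2nncc2CN2C(=O)C3(C(C#N)=C(N)Oc4c(N)cc5nc6ccccc6nc5c43)c3ccccc32)c(C)c1` share one core and differ only in the aryl group on an aromatic nitrogen. In a functional assay on HCT-116 cells (Homo sapiens) for antiproliferative activity, read by MTT assay, with a stated time of 48 h (a lower number here means a stronger inhibitor, a higher number a weaker inhibitor), compound 1 gives 10300 nM. In this assay compound 2 gives 12400 nM. For compound 3 this assay reports only the limit > 50000 nM, not a number. a 1.2-fold higher number from compound 1 to compound 2 (0.08 log units; within the scatter). an at least 4.8-fold higher number from compound 1 to compound 3 (0.68 log units; beyond the scatter) and an at least 4.0-fold higher number from compound 2 to compound 3 (0.60 log units; beyond the scatter), so compound 3 is the weakest of the three. Compound 4 `COc1cc(-n2nncc2CN2C(=O)C3(C(C#N)=C(N)Oc4c(N)cc5nc6ccccc6nc5c43)c3ccccc32)c(OC)cc1Cl` carries 4-chloro-2,5-dimethoxyphenyl in place of 2,4,6-trimethylphenyl on an aromatic nitrogen. Among the compounds with values here, no measured step covers this replacement; the two steps into compound 3 show only that the aryl group can shift the number beyond the scatter. Compound 4 is therefore expected near 25000 nM, between 6000 nM and 100000 nM. That estimate means an expected step of an at least 2.0-fold lower number from compound 3 to compound 4 (0.30 log units; that floor lies within the scatter).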

Compound 4, half-maximal inhibitory concentration: > 50000 nM
Compound 4 ended at the assay's limit; the forecaster's own chance of this, stated with the estimate: 40%; at least 2.0-fold (0.30 log units) between middle value and limit.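

In this assay, 4-chloro-2,5-dimethoxyphenyl on this aromatic nitrogen gives an at least 4.0-fold higher number from compound 2 to compound 4 (0.60 log units; beyond the scatter) and an at least 4.8-fold higher number from compound 1 to compound 4 (0.68 log units; beyond the scatter). So a second aryl group, with chlorine and oxygen atoms rather than only carbon, joins 2,4,6-trimethylphenyl well short of compound 1 and compound 2. The step between compound 3 and compound 4 cannot be read because each compound is recorded only as a limit, not a number: the limit of > 50000 nM in this assay, at which 2 of the 4 values shown sit.

Which part of the 4-chloro-2,5-dimethoxyphenyl group accounts for the loss stays open. So does whether a plain phenyl, or an aryl group bearing an amine or a carboxylic acid, would give a lower number than compound 1.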